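The compounds below may be only part of what the source reports. "The series", "measured", "known", "first", "only" and "open" are said of these compounds alone.

Measured in a functional assay on MCF7 cells (Homo sapiens) for inhibition, read by MTT assay, with a stated time of 72 h; a lower number here means a stronger inhibitor, a higher number a weaker inhibitor:
- compound 1 `CC(C)=CCC[C@H](C)c1ccc(C)c(CNCC2CCNCC2)c1O`: > 20000 nM (a limit).
- compound 2 `CCOC(CCNCc1c(C)ccc([C@@H](C)CCC=C(C)C)c1O)OCC`: 10300 nM.

Compound 1 has only a limit in this assay, > 20000 nM, and no number. Compound 3 `CC(C)=CCC[C@H](C)c1ccc(C)c(CO)c1O` is reached by hydroxy in place of ((piperidin-4-yl)methyl)amino on a saturated chain carbon bound to an aromatic carbon, with hydroxy in place of ((piperidin-4-yl)methyl)amino on a saturated chain carbon bound to an aromatic carbon. Among the compounds with values here, the only measured step, an at least 1.9-fold lower number from compound 1 to compound 2 (0.28 log units; that floor lies within the scatter), keeps the amine nitrogen that compound 3 loses, so it bears on this change only loosely. The expected change is an at least 1.2-fold lower number from compound 1 to compound 3 (0.09 log units; that floor lies within the scatter), small and towards a lower number, hardly beyond the scatter. For compound 3 the estimate is 16000 nM, with an expected range of 6000 nM to 40000 nM.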

Compound 3, half-maximal inhibitory concentration: > 20000 nM
Compound 3 gave a limit, no number; the forecaster's own chance of this, stated with the estimate: 40%; middle value at least 1.2-fold (0.09 log units) from the limit.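

Compound 1 and compound 3 both carry only limits in this assay, not numbers, so the step between them cannot be read. On these data alone, whether hydroxy in place of ((piperidin-4-yl)methyl)amino changes inhibition at all remains open.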